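The source may report more compounds than this note shows. Statements on the series, on what has been measured and on what is new or still open speak of the compounds shown alone.

Working notes on the series. Compound 1 `Cc1ccc(-c2ccc3cccnc3n2)cc1C`, compound 2 `N#Cc1cccc(-c2cnc3cccnc3c2)c1` and compound 3 `Cc1cccc(-c2cnc3cccnc3c2)c1` share the same bicyclic core but differ in where the phenyl ring is attached and in what the phenyl ring carries. In a functional assay on CHO cells for antagonist activity at metabotropic glutamate receptor 5 (Rattus norvegicus), read by calcium flux (on this read-out lower numbers stand for stronger inhibition and higher numbers for weaker inhibition), compound 1 gives 45 nM, compound 2 gives 18600 nM and compound 3 gives 15700 nM. On these three numbers compound 3 stands second highest, close to compound 2 and far from compound 1. Among the compounds with values here, the one single-point step available, a 1.2-fold lower number from compound 2 to compound 3 (0.07 log units; within the scatter), concerns the substituent on the phenyl ring of the core of compound 3.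

Compound 4 `Cc1ccc(-c2cnc3cccnc3c2)cc1C` is the next member. It differs from compound 3 by methyl in place of hydrogen on an aromatic carbon, ortho to a methyl group and para to a large group. Within the data shown here, no measured step covers the addition of a second methyl on this phenyl ring, and the pair of compound 1 and compound 4, which carry the same dimethylphenyl on differently attached cores, has no step either. Only the small step from compound 2 to compound 3 bears on the question, and it suggests that substitution on this phenyl ring has so far moved this assay little. Compound 4 is therefore expected to sit close to compound 3, with an expected step of a 1.6-fold lower number from compound 3 to compound 4 (0.20 log units; within the scatter) that may fall within the scatter; the estimate for compound 4 in this assay is 10000 nM, between 3000 nM and 30000 nM.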

Compound 4, half-maximal inhibitory concentration: 12000 nM
Estimate against measurement, compound 4: 1.2-fold (0.08 log units) below; low and high end bracket the measured number.
By their numbers in this assay, from the lowest: compound 1; then compounds 4, 3 and 2 (each within the scatter of the next).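

In this assay the step of a 1.3-fold lower number from compound 3 to compound 4 (0.12 log units; within the scatter) lies within the scatter, so a methyl on this aromatic carbon, ortho to a methyl group and para to a large group, cannot be told apart from hydrogen on the core of compound 4. Within the data shown here, the earlier step exchanged one substituent for another at a single place on the phenyl ring, whereas this one adds a second methyl at a further carbon of that ring and gives the first reading for this position. On this core, both steps read so far on the phenyl ring now stay within the scatter, and no data at hand bear on the reason for this outcome.

With the same dimethylphenyl on a differently attached core, compound 1 gives 45 nM against compound 4 at 12000 nM in this assay, which leaves open how the same methyl in place of hydrogen would read on the core of compound 1. Also open, on these data alone, is whether a methoxy group, a fluorine atom or an amine on this aromatic carbon would move the number on the core of compound 4 any further than methyl does.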